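Swapping the Hydrazone Aryl Group in a Triazole Series

A few compounds are considered here, and "the series" means these few. Any claim that something is new, unique, unknown or untested is made for them only; others in the source may bear on it.

Compounds measured so far:
- compound 1, `Fc1ccccc1CSc1nnc(-c2ccncc2)n1-c1ccccc1`: > 50000 nM
- compound 2, `Clc1ccccc1CSc1nnc(-c2ccncc2)n1-c1ccccc1`: 18100 nM
- compound 3, `O=C(CSc1nnc(-c2ccncc2)n1-c1ccccc1)N/N=C/c1ccc([N+](=O)[O-])cc1`: 15300 nM

In a functional assay on MCF7 cells (Homo sapiens) for inhibition, read by MTT assay, with a stated time of 48 h (a lower number here means a stronger inhibitor, a higher number a weaker inhibitor), compound 1 gives only a limit, > 50000 nM, not a number (the limit of > 50000 nM in this assay, at which 1 of the 3 values shown sits). Compound 2 gives 18100 nM, a step of an at least 2.7-fold lower number from compound 1 to compound 2 (0.44 log units; beyond the scatter). Compound 3 has the lowest of the two numbers, yet its gap to compound 2 is within the scatter, so the two are not separable.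

Compound 4, `O=C(CSc1nnc(-c2ccncc2)n1-c1ccccc1)N/N=C/C=C/c1ccccc1`, differs from compound 3 by 2-phenylethenyl in place of 4-nitrophenyl on a carbon with a double bond to nitrogen. Among the measured compounds shown here, no measured step touches this part of the molecule, so there is no measured guide. Compound 4 is therefore expected to stay close to compound 3, with a step of a 1.0-fold lower number from compound 3 to compound 4 (0.01 log units; within the scatter), and an estimate of 15000 nM, in the range 5000 nM to 45000 nM.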

Compound 4, half-maximal inhibitory concentration: 11200 nM
Estimate against measurement, compound 4: 1.3-fold (0.13 log units) above; low and high end bracket the measured number.
By their numbers in this assay, from the lowest: compounds 4, 3 and 2 (each within the scatter of the next). At a limit, above all of these: compound 1.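

Putting 2-phenylethenyl in place of 4-nitrophenyl on a carbon with a double bond to nitrogen gives a 1.4-fold lower number from compound 3 to compound 4 (0.14 log units; within the scatter) and so leaves the two compounds inseparable. Among the compounds shown here, this is the first measured change at this position, and it shows that a group of carbon only, without the nitrogen and oxygen atoms of 4-nitrophenyl, can stand here with a number in the same range. Nothing available bears on why.

Still open, as far as these compounds go, is how an amine, a carboxylic acid or a longer chain on this carbon would read. From the compounds shown here alone, whether any group here can move the number beyond the scatter also remains unknown.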